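Removing the para chloro from a hydrazone: compound 4 expected

The source may report more compounds than this note shows. Statements on the series, on what has been measured and on what is new or still open speak of the compounds shown alone.

Measured compounds and their values:
Compound 1 `Cc1ccc(C(/C=C/c2ccc(F)cc2)=N\Nc2nncc3ccccc23)cc1`: 0.55 nM
Compound 2 `Clc1ccc(C(/C=C/c2ccccc2)=N\Nc2nncc3ccccc23)cc1`: 0.53 nM
Compound 3 `COc1ccc(NC(=S)NNc2nncc3ccccc23)cc1`: 7.2 nM

Of the compounds shown here, three share a common hydrazine-bearing core and have been tested in a functional assay on SF-295 cells (Homo sapiens) for antiproliferative activity, read by sulforhodamine B assay, with a stated time of 72 h; a lower number here means a stronger inhibitor, a higher number a weaker inhibitor. Compound 1 gives 0.55 nM, compound 2 gives 0.53 nM and compound 3, a thiourea rather than a hydrazone, gives 7.2 nM. Compound 2 shows the lowest number of the three, but compound 1 lies within the usual scatter of it, so no order between those two can be claimed; compound 3 sits beyond the scatter above both.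

Compound 4 `C(=C/c1ccccc1)\C(=N\Nc1nncc2ccccc12)c1ccccc1` has not yet been measured. It differs from compound 2 in one place: hydrogen in place of chloro on an aromatic carbon. Among the measured compounds shown here, the data hold no measured step of this kind, and compound 1 and compound 2 differ at two places at once, so they say nothing about the chloro alone. The step from compound 2 to compound 4 is therefore expected to be small, most likely within the scatter, with a slightly higher number somewhat more plausible than a lower one.

On that basis compound 4 is estimated at 0.9 nM in this assay, in a range from 0.3 nM to 3 nM; the expected step is a 1.7-fold higher number from compound 2 to compound 4 (0.23 log units; within the scatter).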

Compound 4, half-maximal inhibitory concentration: 0.33 nM
The estimate for compound 4 lay 2.7-fold (0.44 log units) above the measured number; the measured number falls inside the stated range.
By their numbers in this assay, from the lowest: compounds 4, 2 and 1 (each within the scatter of the next); then compound 3.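

In this assay the change from 4-chlorophenyl to phenyl gives a 1.6-fold lower number from compound 2 to compound 4 (0.21 log units; within the scatter) and so stays within the scatter. Among the compounds shown here, this is the first single-place step, and it isolates what the comparison of compound 1 with compound 2 could not, as those two differ at two places at once. For this one pair, the chloro on the aromatic carbon para to a large group is not needed to keep the number at this level, and compound 2 and compound 4 cannot be put in any order. The compounds shown give no measurement that could account for this result.

Going by these compounds, what remains open is how far this tolerance extends, since hydrogen and chloro are the only two substituents compared at this place with all else held constant, and a single pair cannot show whether an amine, a carboxylic acid or a longer chain there would leave the number unchanged. On these data alone, it also remains open what the methyl of compound 1 and the fluoro on its other ring each contribute alone.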